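This account rests on a few compounds, and the source may have more. Where it says the series, first, only, none or still open, it means among the compounds named here.

Measured so far:
compound 1 `N=c1oc2ccc(Br)cc2cc1C(=O)NC1CCCCC1` gives 8%
compound 2 `COc1cccc2cc(C(=O)NCC(=O)O)c(=O)oc12` gives 15%
compound 3 `O=C(NCC(O)CO)c1cc2cc(Cl)ccc2oc1=O` gives 1%

In an assay on HeLa cells for displacement of a labelled ligand from adenosine receptor A3 (Homo sapiens), read by scintillation counting, with a stated time of 180 min, tested at 10 uM (on this read-out lower numbers stand for less inhibition and higher numbers for more inhibition at the one concentration tested (going by the name of the read-out)), compound 2 stands highest of the three numbers, though its value and that of compound 1 lie within the scatter of each other, while compound 3 sits beyond the scatter below it. Compound 4 `O=C(O)CNC(=O)c1cc2ccccc2oc1=O` differs from compound 2 by hydrogen in place of methoxy on an aromatic carbon. Among the compounds with values here, no measured pair shows this change, so nothing here tells how it should shift the read-out. With all three measured values low, the author expects the step of a number 5 percentage points lower from compound 2 to compound 4 (within the scatter) to be small, if anything slightly downward, and not beyond the scatter. Compound 4 is therefore estimated at 10%, with a range from 0% to 25%.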

Compound 4, a percentage reported as inhibition, at one concentration (the size of the read-out at that concentration, not a potency): 0%
Beside the measured number, compound 4's estimate is 10 percentage points above it; the range from low to high includes it.
By their numbers in this assay, from the lowest: compounds 4, 3, 1 and 2 (each within the scatter of the next, the first and the last beyond it).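

In this assay, within the data shown here, the step of a number 15 percentage points lower from compound 2 to compound 4 (beyond the scatter) on replacing methoxy with hydrogen is the first measured change in one place. It shows that this aromatic carbon, ortho to a fused ring and meta to a fused ring, is a position where the read-out can shift with the group it carries, although both numbers remain low. No available evidence accounts for the step. From the compounds shown here alone, whether an ethoxy group, a hydroxyl group or an amine at this position would keep or raise the number remains open. So does whether the same change would give a similar step with a side chain other than the one with the carboxylic acid.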